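The compounds below may be only part of what the source reports. "The series", "measured", "known", "first", "only" and "open" are said of these compounds alone.

Measured so far:
- compound 1 `CCCCCCCCc1c(O)cc(C)oc1=O`: 145000 nM
- compound 2 `Cc1cc(O)c(C(=S)NC2CCCCC2)c(=O)o1`: 177000 nM

In an ADME assay on L929 cells (Mus musculus, culture collection number NCTC 929) for cytotoxicity, read by MTT assay, with a stated time of 72 h (a higher number here means a weaker inhibitor, a lower number a stronger inhibitor), compound 1 gives 145000 nM and compound 2 gives 177000 nM. These two values lie within the usual scatter of each other, so they cannot be ranked. Among the compounds with values here, compound 1 therefore stands level with the only other measured compound.

The next compound to be measured is compound 3 `CCCCCCCCCCCCCCc1c(O)cc(C)oc1=O`. It differs from compound 1 by one change to the chain: hexyl in place of hydrogen on a saturated chain carbon, eight bonds along the chain from an aromatic carbon. This places hexyl in place of hydrogen on a saturated chain carbon, eight bonds along the chain from an aromatic carbon. The same difference can also be read as methyl to heptyl.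

Within the data shown here, no pair of measured compounds differs in one place, so the series offers no measured guide to the effect of this change. The estimate rests on compound 1 at 145000 nM and is kept wide. A small move to a lower number in this assay is expected, and it may not clear the scatter: the estimated step is a 1.7-fold lower number from compound 1 to compound 3 (0.23 log units; within the scatter). For compound 3 the expected value is 85000 nM, with an estimated range of 30000 nM to 200000 nM.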

Compound 3, half-maximal inhibitory concentration: 24100 nM
Compound 3: middle estimate off by 3.5-fold (0.55 log units), on the high side, and the stated range ends above it.
By their numbers in this assay, from the lowest: compound 3; then compounds 1 and 2 (each within the scatter of the next).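

Within the data shown here, this is the first change whose effect can be read: in this assay, hexyl in place of hydrogen on a saturated chain carbon, eight bonds along the chain from an aromatic carbon, gives a 6.0-fold lower number from compound 1 to compound 3 (0.78 log units; beyond the scatter). The entering hexyl carries no ring, no hydrogen-bond donors or acceptors and no net charge, so this structural difference consists of saturated carbon alone, and this chain position is shown to be one where such a change can move the number beyond the scatter. No measurement available here accounts for the step.

A single step gives the size of one change and cannot show whether the number follows chain length in a steady way or whether a longer chain would carry the move further. It also leaves open whether the move depends on saturated carbon, which a carboxylic acid, an amine or a phenyl ring in place of hexyl at this same place would test.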